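Trifluoromethyl on the phenyl ring of an oxazolidinone acid

This account rests on a few compounds, and the source may have more. Where it says the series, first, only, none or still open, it means among the compounds named here.

Measured so far:
compound 1 `CCCc1cccc(C[C@H](O)/C=C/[C@H]2CCC(=S)N2CCCCCCC(=O)O)c1`: > 10000 nM
compound 2 `O=C(O)CCCSCCN1C(=O)SC[C@@H]1/C=C/[C@@H](O)Cc1ccccc1`: > 10000 nM
compound 3 `Cc1cccc(C[C@H](O)/C=C/[C@H]2CCC(=S)N2CCSCCCC(=O)O)c1`: 2800 nM

In an assay on CHO cells for displacement of a labelled ligand from prostaglandin E2 receptor EP1 subtype (Mus musculus), read by scintillation counting, with a stated time of 20 min (on this read-out lower numbers stand for stronger inhibition and higher numbers for weaker inhibition), compound 2 gives only a limit, > 10000 nM, and no number. Compound 1 likewise sits at a limit in this assay, > 10000 nM; compound 3, with a methyl group on its phenyl ring and a different core, gives 2800 nM. Thus two of the three values rest at the limit of > 10000 nM in this assay, at which 2 of the 3 values shown sit, and compound 2 stands among the weakest of what is shown, at the point where the assay stops reporting numbers.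

Compound 4 `O=C(O)CCCSCCN1C(=O)SC[C@@H]1/C=C/[C@@H](O)Cc1cccc(C(F)(F)F)c1` differs from compound 2 in one place: trifluoromethyl in place of hydrogen on an aromatic carbon. Among the measured compounds shown here, no measured pair records this change, so its size is unknown here. The expectation is a step from compound 2 to compound 4 that is small or, at most, modestly toward stronger inhibition, an at least 1.2-fold lower number from compound 2 to compound 4 (0.09 log units; that floor lies within the scatter), with a real chance that this assay again reports only a limit. Compound 4 is accordingly estimated at 8000 nM, within a range from 1500 nM to 30000 nM.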

Compound 4, inhibition constant: > 10000 nM
Compound 4: only a limit was reported; the forecaster's own chance of this, stated with the estimate: 50%; at least 1.2-fold (0.09 log units) between middle value and limit.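

Among the compounds shown here, compound 4 gives only a limit, > 10000 nM, and compound 2 also rests at a limit, so no step between compound 2 and compound 4 can be read. The compounds shown leave open whether trifluoromethyl in place of hydrogen on an aromatic carbon changes the read-out in either direction.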